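This account rests on a few compounds, and the source may have more. Where it says the series, first, only, none or still open, it means among the compounds named here.

Working notes on the series. Three compounds carry numbers in an assay on HEK-293T cells for displacement of a labelled ligand from corticotropin-releasing factor receptor 1 (Homo sapiens), read by scintillation counting, with a stated time of 2 h; on this read-out lower numbers stand for stronger inhibition and higher numbers for weaker inhibition. Compound 1 `CCN(C)c1cc(C)nc2c1NC(=O)CN2c1ccc(C(C)C)cc1Br` gives 16.4 nM in this assay. Compound 3 `Cc1cc(N(C)C)c2c(n1)N(c1ccc(C(C)C)cc1Br)CC(=O)N2CCCCF` gives 21.6 nM in this assay; the values of compound 1 and compound 3 sit within the scatter of each other. Compound 2 `CCCCN(CC)c1cc(C)nc2c1NC(=O)CN2c1ccc(Br)cc1Br` gives 1.3 nM in this assay, the lowest of the three numbers, beyond the scatter from compound 1 and further still from compound 3.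

Compound 4 `CCCCN(CC)c1cc(C)nc2c1NC(=O)CN2c1ccc(Cl)cc1C` has not yet been measured. Its difference from compound 2 is 4-chloro-2-methylphenyl in place of 2,4-dibromophenyl on a nitrogen on an aromatic ring in a ring. Going by the values given here, no pair of measured compounds differs in this place alone, so no measured step sets the size of what to expect; the only guide is the standing of compound 2 at 1.3 nM. The expected step of a 2.3-fold higher number from compound 2 to compound 4 (0.36 log units; beyond the scatter) is a small rise in the number, near the edge of the scatter rather than far beyond it. Compound 4 is estimated at 3 nM in this assay, with a range from 1 nM to 12 nM.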

Compound 4, inhibition constant: 5.4 nM
Compound 4: middle estimate off by 1.8-fold (0.26 log units), on the low side; low and high end bracket the measured number.
By their numbers in this assay, from the lowest: compound 2; then compound 4; then compounds 1 and 3 (each within the scatter of the next).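

Going by these compounds alone, this is the first measured step at this position: with the rest of the structure unchanged, 4-chloro-2-methylphenyl in place of 2,4-dibromophenyl gives a 4.2-fold higher number from compound 2 to compound 4 (0.62 log units; beyond the scatter) in this assay. The step is modest but beyond the scatter, so the number responds to this aryl change on the ring nitrogen even though the two groups have the same count of heavy atoms, and neither carries a hydrogen-bond donor, a hydrogen-bond acceptor or a net charge. No available evidence accounts for the size or direction of the step.

Going by these compounds, the change replaces both bromines at once, so the share of the step belonging to each replacement stays open. Groups such as 2-bromo-4-chlorophenyl or 4-bromo-2-methylphenyl at this position could separate the two replacements.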